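A few compounds are considered here, and "the series" means these few. Any claim that something is new, unique, unknown or untested is made for them only; others in the source may bear on it.

Measured so far:
compound 1 `O=C(Nc1nc(-c2ccccc2)nc2c1nnn2Cc1ccccc1)C1CCCCC1` — 12 nM
compound 2 `COc1ccc(Cl)cc1C(=O)Nc1nc(-c2ccccc2)nc2c1nnn2Cc1ccccc1` — 7150 nM

In an assay (strain Wistar) for displacement of a labelled ligand from adenosine receptor A1 (Rattus norvegicus), read by scintillation counting (a lower number here means a stronger inhibitor, a higher number a weaker inhibitor), compound 2 gives the highest of the two numbers; its nearest neighbour is compound 1, separated by the step of a 600-fold higher number from compound 1 to compound 2 (2.78 log units; beyond the scatter). Compound 3 `O=C(Nc1nc(-c2ccccc2)nc2c1nnn2Cc1ccccc1)c1ccccc1C(F)(F)F` differs from compound 2 by 2-(trifluoromethyl)phenyl in place of 5-chloro-2-methoxyphenyl on a carbonyl carbon. Within the data shown here, only that one step speaks to the present change, and it shows that replacing cyclohexyl with a substituted phenyl on the carbonyl carbon produced a large loss. Compound 3 keeps a substituted phenyl there, so the number for compound 3 is expected to stay far from that of compound 1, with an estimated step of a 1.8-fold lower number from compound 2 to compound 3 (0.25 log units; within the scatter) that lies inside the scatter. Compound 3 is estimated at 4000 nM, between 600 nM and 25000 nM.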

Compound 3, inhibition constant: 550 nM
Estimate against measurement, compound 3: 7.3-fold (0.86 log units) above; measured number outside the range, below it.
By their numbers in this assay, from the lowest: compound 1; then compound 3; then compound 2.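

In this assay, the kind of substituted phenyl on the carbonyl carbon matters: 2-(trifluoromethyl)phenyl in place of 5-chloro-2-methoxyphenyl gives a 13-fold lower number from compound 2 to compound 3 (1.11 log units; beyond the scatter). The large loss seen on leaving cyclohexyl is therefore not the same for every substituted phenyl, yet 2-(trifluoromethyl)phenyl in place of cyclohexyl still gives a 46-fold higher number from compound 1 to compound 3 (1.66 log units; beyond the scatter). Nothing available explains the difference between these groups.

Still open, from the compounds shown here alone, is how unsubstituted phenyl or cyclopentyl on the carbonyl carbon would compare with cyclohexyl. Also open, going by these compounds, is whether the chlorine or the methoxy group of 5-chloro-2-methoxyphenyl accounts for the gap to compound 3.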